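Replacing the cyclobutyl ether of compound 3 with an azetidine

The source may hold more compounds than are shown below. What is called first, only, known or untested is meant among the compounds shown, and "the series" means these compounds.

Compound 3 `COc1ccc(-c2ccc(CO[C@H]3C[C@@H](N=C=S)C3)c(F)c2)cc1F` gives the lowest number of the three compounds in an assay on isolated protein for inhibition of N-acylethanolamine-hydrolyzing acid amidase (Homo sapiens), read by fluorescence, with a stated time of 90 min (on this read-out lower numbers stand for stronger inhibition and higher numbers for weaker inhibition), at 20.6 nM. Compound 1 `CCOc1ccc(-c2ccc(CO[C@H]3C[C@@H](N=C=S)C3)c(F)c2)cc1F` gives 69.2 nM, and compound 2 `COc1ccc(-c2ccc(CO[C@H]3C[C@@H](N=C=S)C3)c(F)c2)cc1OC` gives 58.9 nM; the step of a 3.4-fold lower number from compound 1 to compound 3 (0.53 log units; beyond the scatter) and the step of a 2.9-fold lower number from compound 2 to compound 3 (0.46 log units; beyond the scatter) both lie beyond the scatter. Compound 4 `COc1ccc(-c2ccc(CN3CC(N=C=S)C3)c(F)c2)cc1F` differs from compound 3 by a group of 7 heavy atoms (4 carbon, 2 nitrogen, 1 sulfur; one four-membered non-aromatic ring with 1 hetero atom) in place of a group of 8 heavy atoms (5 carbon, 1 nitrogen, 1 oxygen, 1 sulfur; one four-membered non-aromatic ring of carbon only), on a saturated chain carbon bound to an aromatic carbon. Among the compounds with values here, neither measured step concerns this part of the molecule, so no measured step bears on the change, and its direction cannot be read from the data; a step of uncertain size in either direction is possible. Compound 4 is therefore expected to give about 60 nM, within a range of 15 nM to 250 nM, which would mean an expected step of a 2.9-fold higher number from compound 3 to compound 4 (0.46 log units; beyond the scatter).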

Compound 4, half-maximal inhibitory concentration: 176 nM
For compound 4 the middle estimate is 2.9-fold (0.47 log units) below the measured one, and the stated range covers the measured number.
By their numbers in this assay, from the lowest: compound 3; then compounds 2 and 1 (each within the scatter of the next); then compound 4.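

In this assay, the change on a saturated chain carbon bound to an aromatic carbon gives an 8.5-fold higher number from compound 3 to compound 4 (0.93 log units; beyond the scatter), a larger step than either of those seen among compound 1, compound 2 and compound 3, which all share this group. This one step exchanges the ring and removes the ether oxygen together, so the two changes cannot be told apart. Nothing measured here accounts for the step. Which of the two changes carries the step remains open. So does how a pyrrolidine or a piperidine would read at this place.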